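The source may hold more compounds than are shown below. What is called first, only, known or untested is meant among the compounds shown, and "the series" means these compounds.

Measured so far in an ADME assay on RAW264.7 cells (Mus musculus) for inhibition, read by MTT assay, with a stated time of 72 h, tested at 50 uM; on this read-out higher numbers stand for more inhibition of growth at the one concentration tested and lower numbers for less inhibition of growth
- compound 1 `Cc1ccccc1/N=N/C(=N/NC(=O)c1cc(O)c(O)c(O)c1)c1ccccc1` gives 32.7%
- compound 2 `O=C(N/N=C(/N=N/c1ccccc1Cl)c1ccccc1)c1cc(O)c(O)c(O)c1` gives 24.5%
- compound 3 `O=C(N/N=C(/N=N/c1ccccc1)c1ccccc1)c1cc(O)c(O)c(O)c1` gives 13.6%

Compound 3 stands lowest of the three (13.6%). Compound 4 `COc1ccc(/N=N/C(=N/NC(=O)c2cc(O)c(O)c(O)c2)c2ccccc2)cc1` carries methoxy in place of hydrogen on an aromatic carbon, para to a large group (methoxy in place of hydrogen on an aromatic carbon). The closest evidence is two modest steps ending at compound 3, where hydrogen replaces methyl (a number 19.1 percentage points lower from compound 1 to compound 3 (beyond the scatter)) or chloro (a number 10.9 percentage points lower from compound 2 to compound 3 (beyond the scatter)). Neither step involves methoxy, so the transfer is uncertain. A modest rise in this assay is expected, possibly within the scatter. The estimated step is (a number 8.4 percentage points higher from compound 3 to compound 4 (within the scatter)). For compound 4 the expected value is (22%), with an estimated range (10% to 36%).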

Compound 4, percent growth inhibition at one concentration: 4.51%
Beside the measured number, compound 4's estimate is 17.5 percentage points above it, outside the stated range (below it).
By their numbers in this assay, from the lowest: compounds 4 and 3 (each within the scatter of the next); then compounds 2 and 1 (each within the scatter of the next).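

In this assay, methoxy in place of hydrogen on an aromatic carbon, para to a large group, gives no change beyond the scatter (a number 9.1 percentage points lower from compound 3 to compound 4 (within the scatter)). The gaps to the methyl and chloro compounds are wider (a number 20 percentage points lower from compound 2 to compound 4 (beyond the scatter)) (a number 28.2 percentage points lower from compound 1 to compound 4 (beyond the scatter)), so this methoxy does not share the higher readings of those two groups. No measured evidence available here accounts for this result.

Open, as far as these compounds go, is whether methyl or chloro para to a large group would read like methoxy. Also open, from the compounds shown here alone, is how an amine or a carboxylic acid would read at this place.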